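The compounds below may be only part of what the source reports. "The series", "measured", "known", "first", "only" and "open" are said of these compounds alone.

In an ADME assay on L02 cells (Homo sapiens) for cytotoxicity, read by MTT assay, with a stated time of 24 h (a higher number here means a weaker inhibitor, a lower number a stronger inhibitor), compound 2 `CC(=O)Nc1ccc(S(=O)(=O)N2C/C(=C\c3ccc(C#N)cc3)C(=O)/C(=C/c3ccc(C#N)cc3)C2)cc1` gives 14000 nM, which lies within the scatter of both compound 1 `N#Cc1ccc(/C=C2\CN(S(=O)(=O)c3ccc(F)cc3)C/C(=C\c3ccc(C#N)cc3)C2=O)cc1`, at 18900 nM, and compound 3 `COc1cc(/C=C2\CN(S(=O)(=O)c3ccc(F)cc3)C/C(=C\c3cc(OC)c(OC)c(OC)c3)C2=O)cc(OC)c1`, at 12300 nM. Compound 4 `COc1cc(/C=C2\CN(S(=O)(=O)c3ccc(NC(C)=O)cc3)C/C(=C\c3ccc(C#N)cc3)C2=O)cc(OC)c1OC` departs from compound 2 in one place, with 3,4,5-trimethoxyphenyl in place of 4-cyanophenyl on a double-bonded chain carbon bound to a double-bonded ring carbon.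

For the measured compounds named here, no measured step covers this exchange directly. The only one available, a 1.4-fold lower number from compound 1 to compound 2 (0.13 log units; within the scatter), involves acetamido in place of fluoro on an aromatic carbon, elsewhere in the molecule, and it stays within the scatter. The closest indirect evidence is compound 3, which carries 3,4,5-trimethoxyphenyl on both such chain carbons and gives 12300 nM, so a step beyond the scatter in this assay is not expected in either direction. The expected change is a 1.1-fold lower number from compound 2 to compound 4 (0.03 log units; within the scatter), which is no real shift. For compound 4 the estimated value is 13000 nM, with an expected range from 6500 nM to 26000 nM.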

Compound 4, half-maximal inhibitory concentration: 13600 nM
The estimate for compound 4 lay 1.0-fold (0.02 log units) below the measured number, and the stated range covers the measured number.
By their numbers in this assay, from the lowest: compounds 3, 4, 2 and 1 (each within the scatter of the next).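

In this assay, 3,4,5-trimethoxyphenyl in place of 4-cyanophenyl on a double-bonded chain carbon bound to a double-bonded ring carbon gives a 1.0-fold lower number from compound 2 to compound 4 (0.01 log units; within the scatter), the first direct reading of this exchange among the compounds shown. Compound 3 carries 3,4,5-trimethoxyphenyl on both such chain carbons but differs from compound 2 in more than one place, so it could not isolate the exchange, whereas this single step shows no real shift with acetamido on the other aromatic ring. No measurement is available that would explain this result.

On these data alone, it remains open whether the same exchange would leave the number within the scatter with fluoro in place of acetamido. As far as these compounds go, it is also open how this chain carbon would respond to a phenyl ring bearing a carboxylic acid or an amine.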